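Bromo for Fluoro: A Halogen Swap on Compound 1

The source may report more compounds than this note shows. Statements on the series, on what has been measured and on what is new or still open speak of the compounds shown alone.

Compound 1 `COc1cc(C2=CC(c3ccc(F)cc3)NC(=S)N2)cc(OC)c1OC` was tested in a functional assay on MCF7 cells (Homo sapiens) for antiproliferative activity, read by sulforhodamine B assay, with a stated time of 48 h (a higher number here means a weaker inhibitor, a lower number a stronger inhibitor), where compound 1 gave 125 nM. Among the three measured compounds this is the highest number, meaning the weakest inhibition of cell growth of the three. Compound 2 `COc1cccc(C2=NNC(c3ccc(Cl)cc3)C2O)c1` gives 49 nM in this assay, and compound 3 `COc1ccc(C2=NN(c3ccccc3)C(c3ccc(OC)cc3)C2O)cc1` gives 19 nM, both lower than compound 1 by more than the usual scatter. Within the data shown here, compounds 2 and 3 are of a different build, so no single structural step links either of them to compound 1.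

Compound 4 `COc1cc(C2=CC(c3ccc(Br)cc3)NC(=S)N2)cc(OC)c1OC` keeps the core of compound 1 and differs in one place: bromo in place of fluoro on an aromatic carbon. Among the measured compounds shown here, no measured pair here shows such a swap, so there is no direct precedent to lean on. The step is expected to be small, a 1.3-fold lower number from compound 1 to compound 4 (0.10 log units; within the scatter), at most a modest move to a lower number and likely within the scatter. Compound 4 is therefore estimated at 100 nM, with a range from 40 nM to 300 nM.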

Compound 4, half-maximal inhibitory concentration: 77 nM
For compound 4 the middle estimate is 1.3-fold (0.11 log units) above the measured one; low and high end bracket the measured number.
By their numbers in this assay, from the lowest: compound 3; then compounds 2, 4 and 1 (each within the scatter of the next, the first and the last beyond it).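

Among these compounds, replacing fluoro with bromo on the aromatic ring, para to a large group, gives the first direct reading at this position: in this assay, the step is a 1.6-fold lower number from compound 1 to compound 4 (0.21 log units; within the scatter) and no more than that. The two compounds therefore cannot be told apart, and on the core of compound 1 this position accepts either halogen with the number staying in the same range. No measurement at hand bears on what lies behind this result.

The compounds shown leave open whether a group of another kind at this position, such as an amine or a carboxylic acid, would leave the number where it is or move it. Also open, as far as these compounds go, is whether the same halogen swap would read alike on the core of compound 2, which carries chloro.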